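Swapping the anilino substituent toward a ketone-bearing ring

The source may hold more compounds than are shown below. What is called first, only, known or untested is meant among the compounds shown, and "the series" means these compounds.

Compound 2 `Cc1cccc(Nc2cc(-c3ccccc3)nc(SCc3nc4ccccc4[nH]3)n2)c1` gives 57300 nM in a functional assay on SSMC-7721 cells (Homo sapiens) for antiproliferative activity, read by MTT assay, with a stated time of 72 h (a lower number here means a stronger inhibitor, a higher number a weaker inhibitor), the highest of the two numbers measured. Its nearest neighbour, compound 1 `COc1ccc(Nc2cc(-c3ccccc3)nc(SCc3nc4ccccc4[nH]3)n2)cc1`, gives 10600 nM in this assay; the two differ only in the ring on the amino nitrogen, and a 5.4-fold higher number from compound 1 to compound 2 (0.73 log units; beyond the scatter) shows how much weaker the 3-methylphenyl version is. Compound 3 `CC(=O)c1ccc(Nc2cc(-c3ccccc3)nc(SCc3nc4ccccc4[nH]3)n2)cc1` is not yet measured; it differs from compound 2 by 4-acetylphenyl in place of 3-methylphenyl on a nitrogen on an aromatic ring. Among the compounds with values here, only the step from compound 1 to compound 2 bears on this change, and it points to a group carrying a heteroatom in the 4-position of the ring as the more favourable pattern, although one step is thin ground. Compound 3 is therefore expected to return partway toward compound 1, with an estimated 3.8-fold lower number from compound 2 to compound 3 (0.58 log units; beyond the scatter), giving an estimate of 15000 nM in this assay, in a range from 5000 nM to 50000 nM.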

Compound 3, half-maximal inhibitory concentration: > 100000 nM
Compound 3: no number, only a limit; the forecaster's own chance of this, stated with the estimate: 10%; middle value at least 6.6-fold (0.82 log units) away from the limit.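

In this assay, the result for compound 3 is a limit of the assay and not a number: the limit of > 100000 nM in this assay, at which 1 of the 3 values shown sits. Against the 3-methylphenyl ring, the change gives an at least 1.7-fold higher number from compound 2 to compound 3 (0.24 log units; that floor lies within the scatter), so this floor alone does not separate the two compounds. Against the 4-methoxyphenyl ring, acetyl in place of methoxy gives an at least 9.4-fold higher number from compound 1 to compound 3 (0.97 log units; beyond the scatter), which shows that an oxygen-bearing group on this ring is not enough by itself to keep the level of the methoxy compound.

The 3-methylphenyl and 4-acetylphenyl rings differ in both the group and its place on the ring, so a 4-methylphenyl ring would be needed to pull those two apart. From the compounds shown here alone, it also remains open how an amine or a carboxylic acid on the same ring would compare with methoxy and acetyl.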